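The compounds below may be only part of what the source reports. "The series", "measured", "known", "first", "only" and "open" are said of these compounds alone.

Among the measured compounds shown here, only two compounds with this core have been measured so far in a functional assay on B16-F10 cells (Mus musculus) for antiproliferative activity, read by MTT assay, with a stated time of 48 h; on this read-out higher numbers stand for weaker inhibition and lower numbers for stronger inhibition. In it, compound 1 (`CCCC(C)Oc1ccc(C(=O)/C=C/c2c(/C=C/c3ccc(OC)cc3)cc(OC)cc2OC)cc1`) gives 6.7 ug/mL and compound 2 (`COc1ccc(/C=C/c2cc(OC)cc(OC)c2/C=C/C(=O)c2ccc(OC)cc2)cc1`) gives 5.8 ug/mL. For the measured compounds named here, compound 2 therefore stands level with its only measured neighbour, and neither can be ranked over the other. Compound 3 (`CCN(CC)c1ccc(C(=O)/C=C/c2c(/C=C/c3ccc(OC)cc3)cc(OC)cc2OC)cc1`) keeps the core of compound 2 and alters one group: diethylamino in place of methoxy on an aromatic carbon. In words, diethylamino sits in place of methoxy on an aromatic carbon, para to a large group.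

Going by the values given here, one measured step bears on this change. The step of a 1.2-fold lower number from compound 1 to compound 2 (0.06 log units; within the scatter) replaced 1-methylbutyl with methyl on the oxygen at this same place, and it stayed within the scatter of repeated measurements. Among the compounds with values here, that step kept the oxygen, however, and no measured compound yet carries a nitrogen there, so the guidance is limited. No shift beyond the scatter is expected, in either direction. The expected step, a 1.0-fold higher number from compound 2 to compound 3 (0.01 log units; within the scatter), is therefore small. For compound 3, the estimated value is 6 ug/mL, with an expected range from 2.5 ug/mL to 14 ug/mL.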

Compound 3, half-maximal inhibitory concentration: 8.1 ug/mL
Beside the measured number, compound 3's estimate is 1.4-fold (0.13 log units) below it; low and high end bracket the measured number.
By their numbers in this assay, from the lowest: compounds 2, 1 and 3 (each within the scatter of the next).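

Among the compounds shown here, the new compound is the first here to carry a nitrogen rather than an oxygen on this aromatic carbon, para to a large group, so the change can now be read directly: in this assay, putting diethylamino in place of methoxy gives a 1.4-fold higher number from compound 2 to compound 3 (0.15 log units; within the scatter) and does not separate the two compounds. Putting diethylamino in place of 1-methylbutoxy gives a 1.2-fold higher number from compound 1 to compound 3 (0.08 log units; within the scatter) and likewise leaves the pair level. Earlier, only a change of the chain on the oxygen could be read, whereas these steps show that, across these three compounds, exchanging that oxygen-linked group for diethylamino leaves the number within the usual scatter of repeated measurements.

Going by these compounds, it remains open whether a carboxylic acid, a primary amine or a single fluorine atom at this same place would move the number beyond that scatter, or whether the three groups seen so far simply happen to sit level. Nothing available alongside these numbers offers an explanation for this result.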